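A few compounds are considered here, and "the series" means these few. Any claim that something is new, unique, unknown or untested is made for them only; others in the source may bear on it.

Compound 2 `Cc1nc(-c2ccc(F)cc2)oc1-c1csc(Cc2ccccc2)n1` is one of a pair of closely related compounds tested in an ADME assay on A549 cells (Homo sapiens) for inhibition, read by MTT assay; a higher number here means a weaker inhibitor of growth, a lower number a stronger inhibitor of growth. In this assay compound 2 reaches only > 250 ug/mL, which is a limit of the measurement and not a number. Compound 1 `Cc1nc(-c2ccc(F)cc2)oc1-c1csc(Cc2ccc(F)cc2)n1` is its fluoro counterpart; in this assay compound 1 likewise gives only the limit of > 250 ug/mL. The step that the two limits leave unreadable from compound 1 to compound 2 therefore cannot be sized, since both of its ends sit at the limit of > 250 ug/mL in this assay, at which 2 of the 2 values shown sit. Compound 3 `Cc1nc(-c2ccc(F)cc2)oc1-c1csc(Cc2cccc(Cl)c2)n1` differs from compound 2 by chloro in place of hydrogen on an aromatic carbon of a six-membered aromatic ring of carbon only, meta to a large group; cut one bond further out, this reads benzyl to 3-chlorobenzyl. Among the compounds with values here, no measured step shows what a change on this ring does to growth inhibition, and the only step at hand is unreadable. With both measured compounds at the limit, the expectation for compound 3 is that it also remains weak in this assay, estimated at 250 ug/mL within a range from 80 ug/mL to 600 ug/mL. For compound 3 the estimated step is a number no higher from compound 2 to compound 3 (the limit leaves the size open), expected to be nothing beyond the scatter.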

Compound 3, concentration for 50% growth inhibition: > 250 ug/mL
Compound 3: only a limit was reported; the forecaster's own chance of this, stated with the estimate: 75%; the middle value sits exactly at the limit.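

In this assay compound 3 gives > 250 ug/mL as a limit and not a number. The steps joining compound 1, compound 2 and compound 3 cannot be read, because all three values sit at one limit: the limit of > 250 ug/mL in this assay, at which 3 of the 3 values shown sit. The compounds shown leave open how strongly each inhibits growth, and whether the fluoro or chloro group changes that at all.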